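Aryl swap on the cyclopropane diamide of compound 1

A few compounds are considered here, and "the series" means these few. Any claim that something is new, unique, unknown or untested is made for them only; others in the source may bear on it.

Compound 1 `CN(C)C(=O)c1cc2cnc(Nc3ccc(NC(=O)C4(C(=O)Nc5cccc(Br)c5)CC4)cc3)nc2n1C1CCCC1` gives the highest of the three measured numbers in a functional assay on T47D cells (Homo sapiens) for inhibition, read by CCK-8 assay, with a stated time of 72 h, tested at 10 uM (on this read-out lower numbers stand for less inhibition of growth and higher numbers for more inhibition of growth at the one concentration tested), at 94.6%. The nearest is compound 2 `CN(C)C(=O)c1cc2cnc(Nc3ccc(N)cn3)nc2n1C1CCCC1`, which in this assay gives 61.1%, a gap beyond the scatter. Furthest is compound 3 `Nc1ccc(NC(=O)C2(C(=O)Nc3ccc(F)cc3)CC2)cc1F`, which in this assay gives 30.4%, again beyond the scatter. Compound 3 carries a (4-fluorophenyl)carbamoyl group but not the shared core of compound 1 and compound 2, so the values of compound 1 and compound 3 together say nothing about the aryl group on its own.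

Compound 4 `CN(C)C(=O)c1cc2cnc(Nc3ccc(NC(=O)C4(C(=O)Nc5ccc(F)cc5)CC4)cc3)nc2n1C1CCCC1` differs from compound 1 in one place: 4-fluorophenyl in place of 3-bromophenyl on an amide-type nitrogen. For the measured compounds named here, no measured pair isolates this change. Because compound 1 already reads 94.6%, little room remains upward, and a small downward step in this assay, around the scatter or slightly beyond, is expected. Compound 4 is therefore estimated to give 85% in this assay, between 65% and 97%. The expected step is a number 9.6 percentage points lower from compound 1 to compound 4 (within the scatter).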

Compound 4, percent growth inhibition at one concentration: 105%
The estimate for compound 4 lay 20 percentage points below the measured number; the measured number lies above the stated range.
By their numbers in this assay, from the lowest: compound 3; then compound 2; then compound 1; then compound 4.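

In this assay, 4-fluorophenyl in place of 3-bromophenyl on an amide-type nitrogen gives a number 10.4 percentage points higher from compound 1 to compound 4 (beyond the scatter) and is a modest change, so this position accepts the swap without loss of growth inhibition at the one concentration tested. This is the only pair shown that isolates the aryl group on the shared core, which the comparison of compound 1 with compound 3 could not do. Nothing at hand accounts for the step.

Both the halogen and its ring position change in this pair, so the step cannot be assigned to either one alone. On the same nitrogen, 3-fluorophenyl and 4-bromophenyl would separate the two, while unsubstituted phenyl would show what either halogen adds.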